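A few compounds are considered here, and "the series" means these few. Any claim that something is new, unique, unknown or untested is made for them only; others in the source may bear on it.

Measured so far:
compound 1, `CCCCSc1nnc(COc2cc(C)c3c(C)cc(=O)oc3c2)o1`, gives > 100000 nM.
compound 2, `CCCCCSc1nnc(COc2cc(C)c3c(C)cc(=O)oc3c2)o1`, gives > 100000 nM.

In a functional assay on MDA-MB-231 cells (Homo sapiens) for antiproliferative activity, read by MTT assay, with a stated time of 24 h (on this read-out lower numbers stand for stronger inhibition and higher numbers for weaker inhibition), compound 1 reaches only a limit of the assay, > 100000 nM. Compound 2 likewise reaches only a limit, > 100000 nM. For this reason the step that the two limits leave unreadable from compound 1 to compound 2 cannot be read in size or direction. Both values sit at the limit of > 100000 nM in this assay, at which 2 of the 2 values shown sit, so compound 2 stands at the limit, with nothing measured that separates it from compound 1.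

Compound 3, `CCCCCCSc1nnc(COc2cc(C)c3c(C)cc(=O)oc3c2)o1`, differs from compound 2 by methyl in place of hydrogen on a saturated chain carbon, five bonds along the chain from a sulfur. For the measured compounds named here, the one measured step that resembles it, a step that the two limits leave unreadable from compound 1 to compound 2, is the same kind of change cut one bond closer to the sulfur, and its size is not readable. Going by the values given here, no measured step shows any movement beyond the scatter in this assay. No readable step beyond the scatter is therefore expected from compound 2 to compound 3, an expected step that the limit leaves unreadable from compound 2 to compound 3. Compound 3 is estimated to stay at the limit, with an expected value of 150000 nM and a range from 50000 nM to 500000 nM.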

Compound 3, half-maximal inhibitory concentration: > 100000 nM
Compound 3: only a limit was reported; the forecaster's own chance of this, stated with the estimate: 85%; the middle value does not contradict the limit.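

Compound 3, like compound 1 and compound 2, reaches only a limit in this assay, so no step among these three compounds can be read in size or direction: the limit of > 100000 nM in this assay, at which 3 of the 3 values shown sit.

The compounds shown leave open whether any change to the chain or the shared core would give a measurable value in this assay.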